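The source may hold more compounds than are shown below. What is called first, only, known or untested is meant among the compounds shown, and "the series" means these compounds.

Measured compounds:
compound 1, `O=C(CN(c1ncnc2c1ncn2C1CCCCO1)C1CC1)N[C@@H](CO)C(=O)OCc1ccccc1`: 32.2%
compound 2, `C[C@H](NC(=O)CN(c1nc(Cl)nc2[nH]cnc12)C1CC1)C(=O)O`: 43.5%

Of the compounds shown here, two have been tested in a functional assay on the whole organism (Tail, strain ICR) with Mus musculus as the target, in the tail flick test, with a stated time of 90 min, at a dose of 25 umol/kg by the oral route; a higher number here means a stronger effect of the compound at the dose given, a lower number a weaker effect. Compound 1 `O=C(CN(c1ncnc2c1ncn2C1CCCCO1)C1CC1)N[C@@H](CO)C(=O)OCc1ccccc1` gives 32.2%, and compound 2 `C[C@H](NC(=O)CN(c1nc(Cl)nc2[nH]cnc12)C1CC1)C(=O)O` gives 43.5%. Of these two numbers, compound 1 stands lower; its distance to compound 2 lies beyond the usual scatter of repeated runs, so compound 2 shows the stronger effect at this dose. Compounds 1 and 2 differ in more than one place, so no single change can be read from the gap between them.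

The step of interest leads from compound 1 to compound 3 `CC[C@H](C)[C@H](NC(=O)CN(c1ncnc2c1ncn2C1CCCCO1)C1CC1)C(=O)OCc1ccccc1`, which has not yet been measured. The change is sec-butyl in place of hydroxymethyl on a saturated chain carbon bound to an amide-type nitrogen and a carbonyl carbon. The rest of compound 1 is unchanged. Among the compounds with values here, no measured pair shows what such an exchange does in this assay, so the direction is open, and a large move is not expected. The expected step, a number 5.8 percentage points higher from compound 1 to compound 3 (within the scatter), is small and upward, within the scatter. Compound 3 is estimated at 38%, with a range from 15% to 65%.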

Compound 3, a percentage reported as activity, at one dose (the size of the read-out at that dose, not a potency): 22.6%
Estimate against measurement, compound 3: 15.4 percentage points above, and the stated range covers the measured number.
By their numbers in this assay, from the lowest: compounds 3 and 1 (each within the scatter of the next); then compound 2.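

In this assay, within the data shown here, putting sec-butyl in place of hydroxymethyl on a saturated chain carbon bound to an amide-type nitrogen and a carbonyl carbon gives a number 9.6 percentage points lower from compound 1 to compound 3 (within the scatter), which is the only reading so far of any exchange at this position. The exchange replaces a group that has a hydrogen-bond donor and acceptor with a purely carbon group that has neither, yet the two compounds remain within the scatter of each other, so this one pair gives no clear sign that the exchange matters at this dose. No supporting measurement is available to explain this result.

Going by these compounds, it remains open whether a different group at this place, such as an amine, a carboxylic acid or a longer carbon chain, would move the number beyond the scatter, since one exchange cannot show how much freedom the position allows. A single dose and a single time point also leave open whether compound 1 and compound 3 would stay this close at other doses, because the read-out gives the size of the effect and not a potency.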